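The source may report more compounds than this note shows. Statements on the series, on what has been measured and on what is new or still open speak of the compounds shown alone.

Measured compounds in an ADME assay on isolated protein for inhibition of Dihydrofolate reductase (Homo sapiens), using NADPH; on this read-out higher numbers stand for weaker inhibition and lower numbers for stronger inhibition:

Compound 1 `Nc1nc(N)c2nc(Nc3ccccc3)ccc2n1` gives 1530 nM.
Compound 2 `Nc1nc(N)c2nc(Nc3ccc(O)cc3)ccc2n1` gives 1580 nM.
Compound 3 `Nc1nc(N)c2nc(Nc3cccc4ccccc34)ccc2n1` gives 1100 nM.

Compound 1 stands second highest of the three numbers. Its nearest neighbour is compound 2, and the step from one to the other, a 1.0-fold higher number from compound 1 to compound 2 (0.01 log units; within the scatter), lies within the scatter. Among the measured compounds shown here, compound 3 sits a little lower, but that gap too is within the scatter, so on these three values no compound can be called stronger or weaker than another in this assay.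

Compound 4 `CCCCN(c1ccccc1)c1ccc2nc(N)nc(N)c2n1` differs from compound 1 in one place: butyl in place of hydrogen on a nitrogen on an aromatic ring. For the measured compounds named here, none of the measured steps touches this nitrogen. Going by the values given here, the only step between compounds that differ in one place, from compound 1 to compound 2, concerns a hydroxy on an aromatic carbon and left the number essentially unchanged, so it offers no guide for a butyl on the ring nitrogen. The three measured numbers all lie close together, which speaks for a narrow spread on this core across the changes seen so far, but the change to compound 4 is of a different kind.

For compound 4 the expected step is therefore a 1.0-fold lower number from compound 1 to compound 4 (0.01 log units; within the scatter), with no direction favoured beyond the scatter. Compound 4 is estimated at 1500 nM in this assay, within a range from 500 nM to 4500 nM.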

Compound 4, half-maximal inhibitory concentration: 903 nM
Beside the measured number, compound 4's estimate is 1.7-fold (0.22 log units) above it; the range from low to high includes it.
By their numbers in this assay, from the lowest: compounds 4, 3, 1 and 2 (each within the scatter of the next).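

Among the compounds shown here, on the nitrogen on an aromatic ring, which no earlier step had touched, butyl in place of hydrogen leaves the read-out in this assay within the scatter (a 1.7-fold lower number from compound 1 to compound 4 (0.23 log units; within the scatter)). This pair therefore shows that the hydrogen on this nitrogen can be replaced by a chain of 4 carbon atoms without a change that can be told from the scatter, even though the entering group adds 4 heavy atoms and no hydrogen-bond donors or acceptors. Nothing measured here bears on what lies behind this result, and the step itself gives no direction that can be relied on.

On these data alone, it remains open whether a smaller group such as methyl, a longer chain such as octyl, or a chain ending in an amine or a carboxylic acid on this same nitrogen would move the number beyond the scatter, or whether the number would stay where compound 1 and compound 4 stand. As far as these compounds go, it is equally open whether butyl on this nitrogen would give the same result in compound 2 or compound 3, where the aromatic group on the nitrogen differs from that of compound 1.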